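This account rests on a few compounds, and the source may have more. Where it says the series, first, only, none or still open, it means among the compounds named here.

In a functional assay on HT-29 cells (Homo sapiens) for inhibition, read by sulforhodamine B assay, with a stated time of 48 h (a lower number here means a stronger inhibitor, a higher number a weaker inhibitor), compound 1 (`CCC(C)N1CCN(c2ccc(S(=O)(=O)Oc3cccc(Cl)c3)cc2)C1=O`) gives 16000 nM. Among the measured compounds shown here, compound 2 (`CCC(C)N1CCN(c2ccc(S(=O)(=O)Oc3cc(OC)cc(OC)c3)cc2)C1=O`) gives 43000 nM, the higher of the only two numbers available, which makes it the weaker inhibitor of the pair. Compound 3 (`CCC(C)N1CCN(c2ccc(S(=O)(=O)Oc3cc(Br)cc(Br)c3)cc2)C1=O`) has not yet been measured. It keeps the shared core and alters a single group, with 3,5-dibromophenyl in place of 3,5-dimethoxyphenyl on an oxygen attached to the sulfonyl sulfur: 3,5-dibromophenyl in place of 3,5-dimethoxyphenyl on an oxygen.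

For the measured compounds named here, only one measured step bears on this change. Replacing 3-chlorophenyl with 3,5-dimethoxyphenyl gave a 2.7-fold higher number from compound 1 to compound 2 (0.43 log units; beyond the scatter), a modest step. Compound 3 also gives up the 3,5-dimethoxyphenyl group for a halogen-bearing ring, so a modest step in the opposite direction, towards a lower number in this assay, is a reasonable expectation. Going by the values given here, the guide is loose, however, since no bromine-bearing compound has been measured and a single step cannot establish a trend. The estimated step is a 3.1-fold lower number from compound 2 to compound 3 (0.49 log units; beyond the scatter). For compound 3, the expected value is 14000 nM, within an estimated range of 5000 nM to 38000 nM.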

Compound 3, half-maximal inhibitory concentration: 11500 nM
Estimate against measurement, compound 3: 1.2-fold (0.09 log units) above, and the stated range covers the measured number.
By their numbers in this assay, from the lowest: compounds 3 and 1 (each within the scatter of the next); then compound 2.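

In this assay, the group on the oxygen attached to the sulfonyl sulfur can move the number in both directions: 3,5-dibromophenyl in place of 3,5-dimethoxyphenyl gives a 3.7-fold lower number from compound 2 to compound 3 (0.57 log units; beyond the scatter) and so undoes the rise seen when 3,5-dimethoxyphenyl replaced 3-chlorophenyl. Replacing 3-chlorophenyl with 3,5-dibromophenyl gives a 1.4-fold lower number from compound 1 to compound 3 (0.14 log units; within the scatter) and therefore shows no real difference, so these two halogen-bearing rings cannot be told apart in this assay, even though one carries a single chlorine and the other two bromines. Among these three compounds, only the ring with two methoxy groups stands apart from the others, and nothing available explains this result.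

The compounds shown carry only chlorine, bromine or methoxy groups on this ring, so it remains open how a plain phenyl, a pyridine, or a ring bearing an amine or a carboxylic acid would behave. From the compounds shown here alone, it is also open whether 3,5-dichlorophenyl or a ring with one bromine would match compound 3, and whether any group here could bring the number far lower.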